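This account rests on a few compounds, and the source may have more. Where it says the series, first, only, none or still open, it means among the compounds named here.

Measured so far in a functional assay on A549 cells (Homo sapiens) for antiproliferative activity, read by MTT assay, with a stated time of 48 h; on this read-out lower numbers stand for stronger inhibition and higher numbers for weaker inhibition:
Compound 1 (`Fc1ccc(-c2nn(-c3ccccc3)cc2-c2nc3cc(Cl)ccc3[nH]2)cc1`) gives 1320 nM
Compound 2 (`Fc1ccc(-c2nn(-c3ccccc3)cc2-c2nc3cc(Cl)c(Cl)cc3[nH]2)cc1`) gives 15700 nM

Of these two, compound 2 carries the higher number and is the weaker inhibitor, by a margin beyond the scatter. The next compound is compound 3 (`Clc1ccc(-c2nn(-c3ccccc3)cc2-c2nc3cc(Cl)c(Cl)cc3[nH]2)cc1`), which differs from compound 2 in one group (chloro in place of fluoro on an aromatic carbon). This is chloro in place of fluoro on an aromatic carbon, or 4-fluorophenyl to 4-chlorophenyl.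

Among the compounds with values here, the only measured step is large (a 12-fold higher number from compound 1 to compound 2 (1.08 log units; beyond the scatter)) and also introduces a chloro, but in place of hydrogen and elsewhere in the molecule. Within the data shown here, no measured step exchanges fluoro for chloro, so neither the size nor the direction of that step carries over. The expectation in this assay is therefore no step beyond the scatter, with no firm direction, though the thin data call for a wide range.

For compound 3 the estimated value is 13000 nM with an expected range from 5000 nM to 32000 nM in this estimate. This estimate means an expected 1.2-fold lower number from compound 2 to compound 3 (0.08 log units; within the scatter) in all.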

Compound 3, half-maximal inhibitory concentration: 19100 nM
Estimate against measurement, compound 3: 1.5-fold (0.17 log units) below, and the stated range covers the measured number.
By their numbers in this assay, from the lowest: compound 1; then compounds 2 and 3 (each within the scatter of the next).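

In this assay, exchanging fluoro for chloro on the aromatic carbon para to a large group, which is the change from 4-fluorophenyl to 4-chlorophenyl, gives a 1.2-fold higher number from compound 2 to compound 3 (0.09 log units; within the scatter), so the two groups cannot be told apart at this position on the core of compound 2. Within the data shown here, this is the first reading of this position, since the earlier step, a 12-fold higher number from compound 1 to compound 2 (1.08 log units; beyond the scatter), lay elsewhere in the molecule and was large, whereas this exchange of one halogen for another leaves the number within the scatter. No measured information is available to explain why these two groups read alike here.

On these data alone, the exchange is read only once, on a core that already carries the extra chloro of compound 2, so it remains open whether fluoro and chloro would also read alike on the core of compound 1, whose number is much lower. As far as these compounds go, it is also open whether this position responds at all to groups further from these two halogens, such as a methoxy, an amine or a carboxylic acid, or whether a hydrogen there would give a different number.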